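This account rests on a few compounds, and the source may have more. Where it says the series, first, only, none or still open, it means among the compounds named here.

Measured so far in a functional assay on RPMI8266 cells (Homo sapiens) for inhibition; on this read-out higher numbers stand for weaker inhibition of growth and lower numbers for stronger inhibition of growth:
- compound 1 `COc1cc(/C=C/C(=O)c2cccc(-n3cc(-c4ccc(Cl)cc4)[nH]c3=O)c2)cc(OC)c1OC`: 3920 nM
- compound 2 `O=C(/C=C/c1cccc(O)c1)c1cccc(-n2cc(-c3ccccc3)[nH]c2=O)c1`: 2150 nM
- compound 3 `O=C(/C=C/c1cccc(O)c1)c1cccc(-n2cc(-c3ccc(Cl)cc3)[nH]c2=O)c1`: 1550 nM

Compound 1 lies within the usual scatter of compound 2, so these two cannot be told apart on this assay. Compound 1 gives 3920 nM and compound 3 gives 1550 nM, so compound 3 has the lower number, and that gap lies beyond the scatter.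

The next compound to be tested is compound 4 `COc1ccc(-c2cn(-c3cccc(C(=O)/C=C/c4cc(OC)c(OC)c(OC)c4)c3)c(=O)[nH]2)cc1`. It keeps the frame of compound 1 and changes one group: methoxy in place of chloro on an aromatic carbon. In short, methoxy stands in place of chloro on an aromatic carbon, turning 4-chlorophenyl into 4-methoxyphenyl.

Among the compounds with values here, no measured pair shows this exact swap, so the evidence is indirect. The nearest guide is a 1.4-fold lower number from compound 2 to compound 3 (0.14 log units; within the scatter), where chloro replaces hydrogen on an aromatic carbon. That step stays within the scatter, which gives no sign that this position moves the number much. On this basis, no change beyond the scatter is expected, and the estimated size is a 1.1-fold lower number from compound 1 to compound 4 (0.05 log units; within the scatter).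

Compound 4 is therefore expected at about 3500 nM, with an estimated range from 1800 nM to 7000 nM.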

Compound 4, concentration for 50% growth inhibition: 920 nM
The estimate for compound 4 lay 3.8-fold (0.58 log units) above the measured number, outside the stated range (below it).
By their numbers in this assay, from the lowest: compounds 4, 3, 2 and 1 (each within the scatter of the next, the first and the last beyond it).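

In this assay, turning 4-chlorophenyl into 4-methoxyphenyl gives a 4.3-fold lower number from compound 1 to compound 4 (0.63 log units; beyond the scatter), so the group on this aromatic carbon can move the number by more than the scatter, and here the methoxy side shows the stronger inhibition of growth. The earlier swap at this position, chloro in place of hydrogen, gave a 1.4-fold lower number from compound 2 to compound 3 (0.14 log units; within the scatter) and so offered no sign of such sensitivity, although it was read on a different frame; the position is therefore not indifferent to what sits on it, at least on the frame of compound 1. No measurement here bears on why methoxy and chloro part ways at this place.

The compounds shown leave open whether an amine, a carboxylic acid or a longer chain such as ethoxy on this same carbon would fall nearer to methoxy or to chloro. They also leave open whether methoxy in place of chloro would give a step of similar size on the frame of compound 3, so this single step cannot yet be called a general pattern.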